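The source may hold more compounds than are shown below. What is called first, only, known or untested is meant among the compounds shown, and "the series" means these compounds.

Compound 3 `N=C(S)CCCCCCn1nc(-c2ccccc2)ccc1=O` is one of three compounds examined in a functional assay on the whole organism (stomach) with Rattus norvegicus as the target; on this read-out lower numbers stand for an effect already at smaller amounts and higher numbers for an effect only at larger amounts of compound. For compound 3 the result is only a limit of the assay, > 100 mg/kg. Compound 2 `Cc1ccc(=O)n(CCCCCC(=N)S)n1` likewise reaches only a limit, > 100 mg/kg. Compound 1 `CC/N=C(\S)CCn1nc(-c2ccccc2)ccc1=O` gives 100 mg/kg. Going by the values given here, the single measured step of a number no lower from compound 1 to compound 3 (the limit leaves the size open) is itself bounded by a limit, so its size is not readable; it rests on (the limit of > 100 mg/kg in this assay, at which 2 of the 3 values shown sit). Compound 4 `N=C(S)CCCCCn1nc(-c2ccccc2)ccc1=O` differs from compound 3 by a group of 3 heavy atoms (1 carbon, 1 nitrogen, 1 sulfur; no ring) in place of a group of 4 heavy atoms (2 carbon, 1 nitrogen, 1 sulfur; no ring), on a saturated chain carbon, five bonds along the chain from an aromatic nitrogen. Among the compounds with values here, no measured step touches this position, and the step from compound 1 to compound 3 gives no usable size. Compound 4 is therefore expected to stay close to compound 3, the expected step being a step that the limit leaves unreadable from compound 3 to compound 4. The estimate for compound 4 is 120 mg/kg, between 50 mg/kg and 300 mg/kg.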

Compound 4, dose for half-maximal effect: 23.3 mg/kg
Compound 4: the middle estimate sits 5.2-fold (0.71 log units) above what was measured; the whole stated range lies above it.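

With the group of 3 heavy atoms in place of the group of 4 heavy atoms, on a saturated chain carbon, the step is an at least 4.2-fold lower number from compound 3 to compound 4 (0.63 log units; beyond the scatter), the first readable sign that this position can shift the dose in this assay. Phenyl in place of methyl on an aromatic carbon gives an at least 4.2-fold lower number from compound 2 to compound 4 (0.63 log units; beyond the scatter), and a change in the group on the chain gives a 4.3-fold lower number from compound 1 to compound 4 (0.63 log units; beyond the scatter). The first two of these sizes are bounded only by a limit: the limit of > 100 mg/kg in this assay, at which 2 of the 4 values shown sit.

From the compounds shown here alone, what a still shorter chain would give stays open, as does an amine or a carboxylic acid in place of this group.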